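The source may hold more compounds than are shown below. What is called first, only, known or untested is meant among the compounds shown, and "the series" means these compounds.

Three close relatives of one shared core have been tested in a functional assay on DU-145 cells (Homo sapiens) for cytotoxicity, read by MTT assay; on this read-out higher numbers stand for weaker inhibition and lower numbers for stronger inhibition. Compound 1 `CC(C)=CC[C@@H](OC(=O)CC(C)(O)c1ccccc1)C1=CC(=O)c2c(O)ccc(O)c2C1=O` carries a phenyl; in this assay compound 1 gives only the assay limit > 100000 nM, a boundary rather than a number (the limit of > 100000 nM in this assay, at which 1 of the 3 values shown sits). Compound 2 `CCCC(C)(O)CC(=O)O[C@H](CC=C(C)C)C1=CC(=O)c2c(O)ccc(O)c2C1=O` has a propyl in place of that phenyl, and in this assay compound 2 gives 75000 nM. Compound 3 `CCCCC(C)(O)CC(=O)O[C@H](CC=C(C)C)C1=CC(=O)c2c(O)ccc(O)c2C1=O` has a butyl in place of the phenyl, and in this assay compound 3 gives 76500 nM, the highest of the two numbers, though the step of a 1.0-fold higher number from compound 2 to compound 3 (0.01 log units; within the scatter) lies within the scatter. The steps of an at least 1.3-fold lower number from compound 1 to compound 2 (0.12 log units; that floor lies within the scatter) and an at least 1.3-fold lower number from compound 1 to compound 3 (0.11 log units; that floor lies within the scatter) each set only a floor, and that floor lies within the scatter as well.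

Compound 4 `CCCC(CC(=O)O[C@H](CC=C(C)C)C1=CC(=O)c2c(O)ccc(O)c2C1=O)OC(C)=O` differs from compound 3 by 1-acetoxybutyl in place of 1-hydroxy-1-methylpentyl on a saturated chain carbon bound to a carbonyl carbon. For the measured compounds named here, none of the measured steps exchanges 1-hydroxy-1-methylpentyl for 1-acetoxybutyl, so they give no direction; they show only that changes on this chain have moved the numbers little. The expected step is therefore a 1.0-fold higher number from compound 3 to compound 4 (0.02 log units; within the scatter), none beyond the scatter. Compound 4 is estimated at 80000 nM, with a likely range from 30000 nM to 200000 nM.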

Compound 4, half-maximal inhibitory concentration: 55700 nM
Beside the measured number, compound 4's estimate is 1.4-fold (0.16 log units) above it; the range from low to high includes it.
By their numbers in this assay, from the lowest: compounds 4, 2 and 3 (each within the scatter of the next). At a limit, above all of these: compound 1.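

The earlier steps shown here changed only the carbon group at this position, whereas here the hydroxy group itself gives way: in this assay, 1-acetoxybutyl, with 0 hydrogen-bond donors, replaces 1-hydroxy-1-methylpentyl, which has 1, and the result is a 1.4-fold lower number from compound 3 to compound 4 (0.14 log units; within the scatter). The comparison with the shorter chain gives the same reading, a 1.3-fold lower number from compound 2 to compound 4 (0.13 log units; within the scatter), so neither step shows that a free hydroxy group on this chain matters in this assay. The step of an at least 1.7-fold lower number from compound 1 to compound 4 (0.25 log units; that floor lies within the scatter) sets only a floor, and compound 1 stands at a limit, not a number: the limit of > 100000 nM in this assay, at which 1 of the 4 values shown sits.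

The exchange alters the hydroxy group and the methyl together, so a 1-hydroxybutyl group, which would keep the hydroxy group without the methyl, remains an open case for telling their contributions apart. On these data alone, whether an amine, a carboxylic acid or a chain longer than the butyl of compound 3 at this position would move the number beyond the scatter also remains open.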